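Methoxy for methylsulfonyl on the fused core

The source may report more compounds than this note shows. Statements on the series, on what has been measured and on what is new or still open speak of the compounds shown alone.

Compound 1 `c1ccc(Sc2nn3cc(-c4cc5ccccc5o4)nc3s2)cc1`: in an assay for antagonist activity at proteinase-activated receptor 4 (Homo sapiens), with stated times of 5 min, 50 s and 15 min, in the presence of a further agent that is not named here (on this read-out higher numbers stand for weaker inhibition and lower numbers for stronger inhibition), compound 1 stands at "not determined" (no result reported).
Compound 2 `CS(=O)(=O)c1nn2cc(-c3cc4ccccc4o3)nc2s1`: in this assay compound 2 reports > 30000 nM.

The value of compound 2 is a limit of the assay, not a number, and it sits at the limit of > 30000 nM in this assay, at which 1 of the 2 values shown sits. For the measured compounds named here, compound 1 gives no number at all, so the series holds no measured step and no measured comparison; nothing is known about which of the two is more or less active.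

Compound 3 `COc1nn2cc(-c3cc4ccccc4o3)nc2s1` differs from compound 2 in one place: methoxy in place of methylsulfonyl on an aromatic carbon.

Going by the values given here, with no measured step between any two compounds, there is no basis for expecting the change to move the read-out in either direction beyond the scatter. Among the compounds with values here, the only anchor is compound 2 at its limit, so the expected step from compound 2 to compound 3 in this assay is a number no higher from compound 2 to compound 3 (the limit leaves the size open), that is, no clear gain is expected. Compound 3 is estimated at 30000 nM in this assay, with a range from 5000 nM to 100000 nM, and a limit report is the more likely outcome.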

Compound 3, half-maximal inhibitory concentration: 240 nM
Estimate against measurement, compound 3: 130-fold (2.10 log units) above, and the stated range ends above it.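

In this assay, for the compounds shown here, the aromatic carbon next to the ring nitrogen and next to the ring sulfur now shows a measured response to its substituent, which the earlier compounds could not show: methoxy in place of methylsulfonyl gives an at least 120-fold lower number from compound 2 to compound 3 (2.09 log units; beyond the scatter), a large step beyond the scatter. Compound 2 stands at a limit of the assay and not at a number, so the step has a lower bound but no fixed size: the limit of > 30000 nM in this assay, at which 1 of the 3 values shown sits. With methoxy at this place, the shared core gives a measured inhibition in this assay, but this single pair supports a statement about these two groups only and no general rule for the position.

Compound 1 gives no number, so any step involving it cannot be read, and the compounds shown offer no second comparison at this place. Going by these compounds, it remains open whether the gain is particular to methoxy or extends to other groups here, such as an amine, a longer alkoxy chain like ethoxy, or a carboxylic acid.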